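The source may hold more compounds than are shown below. What is called first, only, known or untested is meant among the compounds shown, and "the series" means these compounds.

Measured so far in an assay on SH-EP1 cells for agonist activity at Neuronal acetylcholine receptor; alpha4/beta2 (Homo sapiens), read by FLIPR and calcium flux; a lower number here means that less compound is needed, a higher number that more compound is needed for the effect:
compound 1 `O=C([C@@H]1C[C@H]1F)N1CC2CC(C1)N2`: 120 nM
compound 2 `C[C@H]1C[C@H]1C(=O)N1CC2CC(C1)N2`: 2200 nM

Going by the values given here, compound 2 stands at the higher of the two numbers in this assay; its only neighbour is compound 1, and the step of an 18-fold higher number from compound 1 to compound 2 (1.26 log units; beyond the scatter) sets the two apart well beyond the scatter.

Compound 3 `C[C@@H]1C[C@H]1C(=O)N1CC2CC(C1)N2` differs from compound 2 only in the drawn configuration: the two compounds have the same atoms and bonds; at least one stereo element is drawn with a configuration in one of them and without one in the other: 1 of 4 stereo elements differ; a stereocentre at a saturated ring carbon is drawn S in compound 2 and R in compound 3. Among the compounds with values here, no measured step bears on a change of configuration alone. Within the data shown here, the one step known, an 18-fold higher number from compound 1 to compound 2 (1.26 log units; beyond the scatter), swaps the substituent on the cyclopropyl ring and therefore gives no guide to what inverting a single stereocentre does. Compound 3 may therefore land on either side of compound 2, and the estimate is placed close to compound 2 with a wide range: compound 3 is expected at 1800 nM (range 300 nM to 10000 nM), a step of a 1.2-fold lower number from compound 2 to compound 3 (0.09 log units; within the scatter).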

Compound 3, half-maximal effective concentration: 190 nM
Compound 3: middle estimate off by 9.5-fold (0.98 log units), on the high side; the measured number lies below the stated range.
By their numbers in this assay, from the lowest: compounds 1 and 3 (each within the scatter of the next); then compound 2.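

The step of a 12-fold lower number from compound 2 to compound 3 (1.06 log units; beyond the scatter) in this assay shows that the configuration at this saturated ring carbon alone can carry a large change, about as large as the earlier step of an 18-fold higher number from compound 1 to compound 2 (1.26 log units; beyond the scatter). The methyl in place of fluoro swap therefore has no single size here: the step of a 1.6-fold higher number from compound 1 to compound 3 (0.20 log units; within the scatter) stays within the scatter, so the large gap to compound 2 cannot be read as a general penalty for methyl. The configuration reading carries one caution: the fact that one of compounds 2 and 3 is drawn with a defined configuration and the other without, at the place where they differ.

Going by these compounds, whether inverting the same stereocentre moves the number as far in the fluoro compound remains open. Also open, on these data alone, is how an ethyl, chloro or hydroxyl group on this cyclopropyl ring would behave in each configuration.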